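Swapping the tetrazole for a triazole on compound 3

The source may report more compounds than this note shows. Statements on the series, on what has been measured and on what is new or still open speak of the compounds shown alone.

Of the compounds shown here, three sharing one core have been tested so far in an ADME assay on NIH3T3 cells (Mus musculus) for cytotoxicity, read by MTT assay, with a stated time of 24 h; a lower number here means a stronger inhibitor, a higher number a weaker inhibitor. Compound 1 `O=C(CSc1nnnn1-c1ccccc1)N/N=c1/scc(-c2ccc(Br)cc2)n1-c1ccccc1` gives 433 ug/mL. Compound 2 `Cc1ccc(-c2cs/c(=N/NC(=O)CSc3nncn3C)n2-c2ccccc2)cc1` gives 130 ug/mL. Compound 3 `Cn1nnnc1SCC(=O)N/N=c1/scc(-c2ccc(Br)cc2)n1-c1ccccc1` gives 19.3 ug/mL, the lowest of the three numbers; compound 2 sits closest, and compound 1 furthest. Within the data shown here, the one step measured between two compounds that differ in a single place is a 22-fold lower number from compound 1 to compound 3 (1.35 log units; beyond the scatter), a large move that came with a small change.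

Compound 4 `Cn1cnnc1SCC(=O)N/N=c1/scc(-c2ccc(Br)cc2)n1-c1ccccc1` is the next compound to be measured. It differs from compound 3 by 4-methyl-4H-1,2,4-triazol-3-yl in place of 1-methyl-1H-tetrazol-5-yl on a sulfur. Among the measured compounds shown here, no measured step isolates this change. Compound 2 carries the same triazole, but it also carries a methyl on the phenyl ring where compound 3 and compound 4 carry a bromine, so its value only hints at what the triazole may do. Given how far compound 3 lies below compound 2, the expectation for compound 4 is a step back toward the other numbers, a 3.1-fold higher number from compound 3 to compound 4 (0.49 log units; beyond the scatter), with compound 4 estimated at 60 ug/mL, within a range of 20 ug/mL to 200 ug/mL.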

Compound 4, half-maximal inhibitory concentration: 58.3 ug/mL
Estimate against measurement, compound 4: 1.0-fold (0.01 log units) above, and the stated range covers the measured number.
By their numbers in this assay, from the lowest: compound 3; then compound 4; then compound 2; then compound 1.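

In this assay, a 3.0-fold higher number from compound 3 to compound 4 (0.48 log units; beyond the scatter) isolates the swap of 1-methyl-1H-tetrazol-5-yl for 4-methyl-4H-1,2,4-triazol-3-yl on the sulfur, showing that the ring itself affects the number even when the rest of the molecule stays fixed. There is also now a direct reading at a second place: a 2.2-fold lower number from compound 2 to compound 4 (0.35 log units; beyond the scatter) comes with bromo in place of methyl on an aromatic carbon, so that change matters too. Against 1-phenyl-1H-tetrazol-5-yl, the triazole gives a 7.4-fold lower number from compound 1 to compound 4 (0.87 log units; beyond the scatter), a smaller drop than a 22-fold lower number from compound 1 to compound 3 (1.35 log units; beyond the scatter), so the size of the gain from leaving the phenyl-bearing tetrazole depends on which methyl-bearing ring replaces it.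

No measurement shown explains why the triazole gives the higher number. Going by these compounds, it also remains open how an amine or a carboxylic acid on the sulfur-linked ring would shift the number.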